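The source may hold more compounds than are shown below. What is called first, only, known or untested is meant among the compounds shown, and "the series" means these compounds.

Three compounds share one core and were each tested in a functional assay on HEK293 cells for antagonist activity at P2X purinoceptor 7 (Homo sapiens), read by FLIPR and calcium flux; a lower number here means a stronger inhibitor, a higher number a weaker inhibitor. Compound 1 `Cc1ccccc1N/C(=N\C#N)NC(NC(=O)CCCc1ccccc1)C(C)(C)C` gives 79.4 nM in this assay. Compound 2 `Cc1ncccc1N/C(=N\C#N)NC(NC(=O)CCCCc1ccccc1)C(C)(C)C` gives 63.1 nM. Among the measured compounds shown here, compound 3 `COc1ccc(C(=O)NC(N/C(=N/C#N)Nc2ccccc2C)C(C)(C)C)cc1` gives 7940 nM, the highest of the three numbers; the step of a 100-fold higher number from compound 1 to compound 3 (2.00 log units; beyond the scatter) is the only single-change step among them, and compound 2 sits further still from compound 3. Compound 4 `COc1ccc(C(=O)NC(N/C(=N/C#N)Nc2ccccc2C)C(C)(C)C)cc1OC` has not yet been measured; it differs from compound 3 by methoxy in place of hydrogen on an aromatic carbon. For the measured compounds named here, no measured pair shows this particular change: the only measured step swaps the entire group on the carbonyl carbon and says nothing about adding a methoxy group to the 4-methoxyphenyl group that both compound 3 and compound 4 carry. With nothing bearing on it, the expected step of a 1.0-fold higher number from compound 3 to compound 4 (0.00 log units; within the scatter) is one that does not go beyond the scatter in either direction. Compound 4 is therefore estimated at 8000 nM, with a range from 2500 nM to 25000 nM.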

Compound 4, half-maximal inhibitory concentration: 5010 nM
Beside the measured number, compound 4's estimate is 1.6-fold (0.20 log units) above it; the range from low to high includes it.
By their numbers in this assay, from the lowest: compounds 2 and 1 (each within the scatter of the next); then compounds 4 and 3 (each within the scatter of the next).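

Placing a further methoxy group on the aromatic carbon ortho to the existing methoxy group, which turns 4-methoxyphenyl into 3,4-dimethoxyphenyl, gives a 1.6-fold lower number from compound 3 to compound 4 (0.20 log units; within the scatter), so these two compounds cannot be told apart and this ring position tolerates the added group. The larger gap remains, at a 63-fold higher number from compound 1 to compound 4 (1.80 log units; beyond the scatter), so the added methoxy group does not bring the aromatic amide close to the 3-phenylpropyl amide. No supporting measurement is available to explain either step.

The compounds shown leave open whether a smaller or different group at this ring position, such as a fluorine atom, a hydroxyl or an amine, would also leave the number within the scatter. They also leave open whether a 3-(3,4-dimethoxyphenyl)propyl group on the carbonyl carbon would match compound 1.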